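Two hydroxyphenyl pyridines and a third to be tested

The source may report more compounds than this note shows. Statements on the series, on what has been measured and on what is new or still open speak of the compounds shown alone.

The compounds in this set share a core carrying a thiophen-3-yl group and two hydroxyphenyl groups, and they were tested in an assay on isolated protein for inhibition of DNA topoisomerase 1 (Homo sapiens), with a stated time of 30 min, tested at 100 uM; on this read-out higher numbers stand for a stronger effect at the one concentration tested and lower numbers for a weaker effect. Compound 1 `Oc1ccc(-c2cc(-c3ccsc3)cc(-c3ccccc3O)n2)cc1` gives 13.8% in this assay. For the measured compounds named here, compound 2 `Oc1cccc(-c2cc(-c3ccsc3)cc(-c3cccc(O)c3)n2)c1` gives 59.2%, the highest of the two numbers recorded, and the gap to compound 1 is beyond the scatter; no single step connects the two, so the pair shows only that the higher value belongs to compound 2. Compound 3 `Oc1ccc(-c2cc(-c3ccsc3)cc(-c3cccc(O)c3)n2)cc1` has the same atoms as compound 2, joined differently: 4-hydroxyphenyl in place of 3-hydroxyphenyl on an aromatic carbon. Going by the values given here, no step between measured compounds matches this change. A moderate fall in this assay is expected, because compound 1, which also carries a 4-hydroxyphenyl group, gives 13.8%. For compound 3 the expected step is a number 21.2 percentage points lower from compound 2 to compound 3 (beyond the scatter). Compound 3 is therefore estimated at 38%, within a range from 15% to 60%.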

Compound 3, a percentage reported as inhibition, at one concentration (the size of the read-out at that concentration, not a potency): 17.1%
For compound 3 the middle estimate is 20.9 percentage points above the measured one, within the range that was stated.
By their numbers in this assay, from the lowest: compounds 1 and 3 (each within the scatter of the next); then compound 2.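

In this assay, 4-hydroxyphenyl in place of 3-hydroxyphenyl on the aromatic carbon next to the ring nitrogen gives a number 42.1 percentage points lower from compound 2 to compound 3 (beyond the scatter), so this single exchange at this position removes most of the effect seen with compound 2. With 4-hydroxyphenyl in that place, 3-hydroxyphenyl in place of 2-hydroxyphenyl on an aromatic carbon gives a number 3.3 percentage points higher from compound 1 to compound 3 (within the scatter), and so this second exchange does not separate the two compounds on this read-out. Nothing measured here explains why the first exchange matters so much and the second does not.

The compounds shown leave open how an aminophenyl or a methoxyphenyl group would read in this place in this assay. They also leave open whether the thiophen-3-yl group contributes to the number seen for compound 2 (59.2%).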